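This account rests on a few compounds, and the source may have more. Where it says the series, first, only, none or still open, it means among the compounds named here.

In a functional assay on CCRF-CEM cells (Homo sapiens) for antiproliferative activity, read by trypan blue exclusion, with a stated time of 72 h (a higher number here means a weaker inhibitor, a lower number a stronger inhibitor), compound 1, whose structure is `CC(Br)C(=O)Nc1cc(C(=O)NC(N)=O)ccc1Cl`, gives 9800 nM. Compound 3, with the structure `CC(Cl)C(=O)Nc1cc(C(=O)NC(N)=O)ccc1Cl`, differs from compound 1 only by chloro in place of bromo on a saturated chain carbon bound to a carbonyl carbon and a saturated chain carbon. For compound 3 the assay reports only a limit, > 20000 nM, and this is the ceiling described by the limit of > 20000 nM in this assay, at which 1 of the 3 values shown sits. The resulting step is an at least 2.0-fold higher number from compound 1 to compound 3 (0.30 log units; that floor lies within the scatter), so the swap from bromo to chloro at that place made compound 3 the weaker of the two, though only the lower bound of the step is known.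

Compound 2, whose structure is `NC(=O)NC(=O)c1cc(NC(=O)CBr)ccc1F`, carries a different core; how that core differs from the core of compound 1 is not broken down here. For compound 2 the assay again gives only a limit, < 10 nM, the floor described by the limit of < 10 nM in this assay, at which 1 of the 3 values shown sits.

Compound 4, with the structure `NC(=O)NC(=O)c1cc(NC(=O)CCl)ccc1F`, has not yet been measured in this assay. It differs from compound 2 by chloro in place of bromo on a saturated chain carbon bound to a carbonyl carbon. Among the measured compounds shown here, this is the same kind of change as the one from compound 1 to compound 3, but the place is not identical: in compound 1 the carbon carrying the halogen is bound to a carbonyl carbon and a saturated chain carbon, whereas in compound 2 it is bound to a carbonyl carbon alone.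

Resting on the step of an at least 2.0-fold higher number from compound 1 to compound 3 (0.30 log units; that floor lies within the scatter), the expected step for compound 4 is an at least 8.0-fold higher number from compound 2 to compound 4 (0.90 log units; beyond the scatter). The estimate for compound 4 in this assay is therefore 80 nM, expected to fall between 10 nM and 600 nM.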

Compound 4, half-maximal inhibitory concentration: 7680 nM
Beside the measured number, compound 4's estimate is 96-fold (1.98 log units) below it, and the stated range ends below it.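

In this assay, putting chloro in place of bromo on a saturated chain carbon bound to a carbonyl carbon gives an at least 760-fold higher number from compound 2 to compound 4 (2.88 log units; beyond the scatter), so on this core the swap costs a large amount of antiproliferative activity. The same kind of swap on the core of compound 1 has a floor that stays within the scatter, so the two results cannot yet be said to match or to differ in size: the same change on two cores in this assay, an at least 2.0-fold higher number (0.30 log units; that floor lies within the scatter) from compound 1 to compound 3 and an at least 760-fold higher number (2.88 log units; beyond the scatter) from compound 2 to compound 4; the limit leaves it open whether they differ What this shows is that a step seen on one core gave no reliable size for the step on the other, but it does not show how large either step really is, since each rests on a limit and only its lower bound is known.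

The compounds shown leave open which part of the difference between the core of compound 1 and the core of compound 2 goes with the large step here. They also leave open how iodo at the same place, or a longer chain carrying the bromo, would read in this assay.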